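The compounds below may be only part of what the source reports. "The series", "measured", "known", "first", "only" and "open" are said of these compounds alone.

Compound 1 `C#Cc1nc2ccccc2n1C` is one of three compounds examined in a functional assay on HCT-116 cells (Homo sapiens) for cytotoxicity, with a stated time of 3 days (on this read-out lower numbers stand for stronger inhibition and higher numbers for weaker inhibition), where compound 1 gives 19400 nM. Going by the values given here, this is the only number recorded among the three. Compound 2 `CC#CC1=Nc2ccccc2C(C)(C)O1` returns the limit > 40000 nM in this assay rather than a number. Compound 3 `C#Cc1nc(-c2ccccc2)cs1` likewise returns the limit > 40000 nM in this assay. Among the compounds with values here, two of the three values thus sit at the limit of > 40000 nM in this assay, at which 2 of the 3 values shown sit, and compound 1 stands alone as the single measured number, itself at the weak end of what this assay reports.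

Compound 4 `Cn1cnc2ccccc21` has not yet been measured in this assay. It differs from compound 1 in one place: hydrogen in place of ethynyl on an aromatic carbon. Within the data shown here, the ethynyl is the only group that leaves, and nothing beyond a hydrogen atom takes its place on the aromatic carbon between the two ring nitrogen atoms. Among the measured compounds shown here, no step between two measured compounds is available to calibrate such a change, so the expectation rests on compound 1 alone and on the two other compounds already sitting at the limit. Compound 4 is expected to be weaker than compound 1. The step is estimated as a 2.3-fold higher number from compound 1 to compound 4 (0.37 log units; beyond the scatter), a move beyond the scatter. For compound 4 the estimate is 45000 nM, between 20000 nM and 100000 nM, and the assay may well return only its limit.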

Compound 4, half-maximal inhibitory concentration: > 40000 nM
Compound 4 was reported as a limit (the forecaster's own chance of this, stated with the estimate: 65%); the middle value is on the limit's open side.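

Swapping the ethynyl for hydrogen on the aromatic carbon between the two ring nitrogen atoms gives an at least 2.0-fold higher number from compound 1 to compound 4 (0.31 log units; beyond the scatter), the first comparison in this set that changes a single place, and it shows that the activity recorded for the shared core in this assay does not survive without the ethynyl at this position. In this assay compound 4 gives > 40000 nM, which is a limit and not a number, so the step fixes a minimum for the change and leaves its true size unknown. Compound 1 therefore remains the only compound here with a measured number, and the loss of this one group is enough to bring the core down to the level of the others: the limit of > 40000 nM in this assay, at which 3 of the 4 values shown sit.

The compounds shown leave open whether the ethynyl itself is needed on this carbon or whether another group there, such as a nitrile, an ethyl or an amine, would keep or improve the activity. They also leave open how the methyl on the neighbouring ring nitrogen contributes, as no compound shown changes that group alone.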